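The compounds below may be only part of what the source reports. "The series", "measured", "known", "first", "only" and "open" are said of these compounds alone.

Measured so far:
compound 1 `O=C(CCCCC1CCSS1)Nc1cccc(C(F)(F)F)c1`: 6.77%
compound 2 `O=C(CCCCC(S)CCS)Nc1cccc(Cl)c1`: "not active" (no number reported)

Both results come from a functional assay on NCI-H460 cells (Homo sapiens) for inhibition, read by MTT assay, with a stated time of 24 h, tested at 10 ug/mL; a lower number here means less inhibition of growth, a higher number more inhibition of growth at the concentration tested. Compound 2 has no number there: it is reported as "not active" (no number reported), which leaves it without a figure from which a step could be measured. The next structure is compound 3 `O=C(CCCCC(S)CCS)Nc1cccc(C(F)(F)F)c1`. The change is trifluoromethyl in place of chloro on an aromatic carbon, with trifluoromethyl in place of chloro on an aromatic carbon, meta to a large group. For the measured compounds named here, no step between measured compounds is available to size this replacement, so any expectation rests on thin evidence. The only figure to hand is that of compound 1, which also carries trifluoromethyl and gives 6.77% in this assay. Against that stands compound 2 at "not active" (no number reported). The step expected in this assay is therefore small and, if it shows at all, upward, with nothing beyond the usual scatter of this read-out. A report with no number would also come as no surprise. Compound 3 is estimated at 7%, with an expected range from 0% to 22%.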

Compound 3, percent growth inhibition at one concentration: 11.4%
Compound 3: the middle estimate sits 4.4 percentage points below what was measured, and the stated range covers the measured number.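

Read in this assay, the first comparison concerns the sulfur-bearing end of the chain: with trifluoromethyl held on the aromatic carbon, a group of 5 heavy atoms with no ring stands in place of the five-membered non-aromatic ring with 2 hetero atoms, and this gives a number 4.6 percentage points higher from compound 1 to compound 3 (within the scatter), so the ring and its open form are not told apart here. Going by these compounds, at the aromatic position, the open-chain series now has a figure with trifluoromethyl, as compound 3 gives 11.4%, while the chloro counterpart, compound 2, stands at "not active" (no number reported), so the step from chloro to trifluoromethyl cannot be read and its size stays unknown. Nothing measured here bears on the reason for these results.

The compounds shown leave open what a nitrile or a methoxy group would give on that aromatic carbon, and whether chloro on the core of compound 1 would yield a number at all. Also open, on these data alone, is what a shorter chain, or a carboxylic acid in place of the sulfur-bearing group, would give in this assay.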